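Cytotoxicity notes: 4-chlorophenyl amide in the methoxyphenyl series

The compounds below may be only part of what the source reports. "The series", "measured", "known", "first", "only" and "open" are said of these compounds alone.

Measured so far in a toxicity assay on THP-1 cells (Homo sapiens) for inhibition; a lower number here means that less compound is tolerated, a higher number that more compound is tolerated:
- compound 1 `COc1ccc(-c2cnc(NC(=O)c3ncc[nH]3)n2C)cc1`: > 100000 nM; this value is a limit of the assay, not a number.
- compound 2 `COc1ccc(-c2cnc(NC(=O)c3ccccc3O)n2C)cc1`: > 100000 nM; again a limit only.
- compound 3 `COc1ccc(-c2cnc(NC(C)=O)n2C)cc1`: > 100000 nM; again a limit only.

Compound 3 thus stands at the same limit as the other two measured compounds in this assay; no number separates them. The three steps among the measured compounds, a step that the two limits leave unreadable from compound 1 to compound 2, a step that the two limits leave unreadable from compound 1 to compound 3 and a step that the two limits leave unreadable from compound 2 to compound 3, are all unreadable for the same reason, (the limit of > 100000 nM in this assay, at which 3 of the 3 values shown sit).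

The next compound, compound 4 `COc1ccc(-c2cnc(NC(=O)c3ccc(Cl)cc3)n2C)cc1`, differs from compound 3 by 4-chlorophenyl in place of methyl on a carbonyl carbon.

Which measured steps bear on this change: all three, but only to the extent that swapping the group on the carbonyl carbon between 1H-imidazol-2-yl, 2-hydroxyphenyl and methyl never brought any value below the limit. Among the measured compounds shown here, the size of any of these steps is unknown, so no direction can be read for the new group; the expectation is simply that compound 4 also stays at or around the limit, with a number no higher from compound 3 to compound 4 (the limit leaves the size open) expected to be no real step.

Estimated for compound 4 in this assay: 100000 nM, range 40000 nM to 300000 nM, most likely reported as a limit again.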

Compound 4, half-maximal cytotoxic concentration: > 100000 nM
Compound 4 ended at the assay's limit (the forecaster's own chance of this, stated with the estimate: 75%); the middle value lies on the limit itself.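

In this assay compound 4 gives > 100000 nM, which is a limit and not a number. The steps linking compound 4 with compound 1, compound 2 and compound 3 therefore cannot be read: the limit of > 100000 nM in this assay, at which 4 of the 4 values shown sit.

The compounds shown leave open whether any group on the carbonyl carbon brings a value inside the measurable range, and how far these four compounds truly differ.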